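The compounds below may be only part of what the source reports. "The series", "measured", "known", "first", "only" and "open" are said of these compounds alone.

Compound 1 `O=c1c(C(=S)Nc2ccccc2)coc2cc(Cl)ccc12` gives 41% in a functional assay on HEp-2 cells (Homo sapiens) for inhibition, read by sulforhodamine B assay, with a stated time of 48 h, tested at 100 uM (a higher number here means more inhibition of growth at the concentration tested, a lower number less inhibition of growth), while compound 2 `O=c1c(C(=S)Nc2ccccc2)coc2cc(Cl)c(Cl)cc12` gives 4%. The step of a number 37 percentage points higher from compound 2 to compound 1 (beyond the scatter) is hydrogen in place of chloro on an aromatic carbon. Compound 3 `O=c1c(C2N=C(c3ccccc3)SS2)coc2cc(Cl)ccc12`, built on a different core, gives 31% in this assay; the difference between the two cores is not broken down here. Compound 4 `O=c1c(C2N=C(c3ccccc3)SS2)coc2ccccc12` is not yet measured. It differs from compound 3 by hydrogen in place of chloro on an aromatic carbon, the same kind of change as from compound 2 to compound 1, though there the chloro that left stood ortho to a second chloro group, whereas in compound 3 no such neighbour is present. Among the compounds with values here, because the earlier step of a number 37 percentage points higher from compound 2 to compound 1 (beyond the scatter) was large, a rise is expected for compound 4, but a smaller one, since the surroundings of the place differ and only one example exists. The expected step is a number 11 percentage points higher from compound 3 to compound 4 (beyond the scatter). Compound 4 is estimated at 42%, between 18% and 66%.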

Compound 4, percent growth inhibition at one concentration: 48%
For compound 4 the middle estimate is 6 percentage points below the measured one, within the range that was stated.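

In this assay hydrogen in place of chloro again goes with more inhibition of growth on the second core, with a number 17 percentage points higher from compound 3 to compound 4 (beyond the scatter) in the same direction as on the first. The direction of the change therefore carries over between these two cores, but its size does not: the same change on two cores in this assay, a number 37 percentage points higher (beyond the scatter) from compound 2 to compound 1 and a number 17 percentage points higher (beyond the scatter) from compound 3 to compound 4, 20 percentage points apart, beyond the scatter of two such steps. Within the data shown here, with only two pairs, this does not show whether the gap comes from the cores themselves or from the second chloro group that compound 2 carries and compound 3 lacks.

The compounds shown hold only chloro or hydrogen on this ring, so the effect of an amine, a methoxy group or a carboxylic acid in that place stays open. Also open, on these data alone, is whether the same order would hold at other concentrations.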